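Benzyl for isopropyl on sulfur, starting from compound 2

The compounds below may be only part of what the source reports. "The series", "measured", "known", "first", "only" and "open" are said of these compounds alone.

In a functional assay on HeLa cells (Homo sapiens) for antiproliferative activity, read by resazurin assay (a higher number here means a weaker inhibitor, a lower number a stronger inhibitor), compound 1 `CCSC(=S)SCC(=O)c1ccc(C)cc1` gives 3980 nM and compound 3 `[C-]#[N+]c1ccc(C(=O)CSC(=S)SCC)cc1` gives 7940 nM. Compound 2 `Cc1ccc(C(=O)CSC(=S)SC(C)C)cc1` gives 25100 nM, the highest number of the three and beyond the scatter from both others.

Compound 4 `Cc1ccc(C(=O)CSC(=S)SCc2ccccc2)cc1` differs from compound 2 by benzyl in place of isopropyl on a sulfur.

The step that bears most directly on this change is a 6.3-fold higher number from compound 1 to compound 2 (0.80 log units; beyond the scatter), where methyl replaces hydrogen on a saturated chain carbon. Benzyl does not carry that added methyl. The other step, a 2.0-fold higher number from compound 1 to compound 3 (0.30 log units; within the scatter), lies on an aromatic carbon and says little about this sulfur. Among the compounds with values here, no measured compound carries a ring on this sulfur, so the uncertainty is wide.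

On the evidence of a 6.3-fold higher number from compound 1 to compound 2 (0.80 log units; beyond the scatter), a modest move to a lower number is expected in this assay. The expected size of the change is a 3.1-fold lower number from compound 2 to compound 4 (0.50 log units; beyond the scatter). The estimate for compound 4 is 8000 nM, with an expected range of 2500 nM to 25000 nM.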

Compound 4, half-maximal inhibitory concentration: 25100 nM
The estimate for compound 4 lay 3.1-fold (0.50 log units) below the measured number, outside the stated range (above it).
By their numbers in this assay, from the lowest: compounds 1 and 3 (each within the scatter of the next); then compounds 2 and 4 (each within the scatter of the next).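

In this assay, a ring on this sulfur now has a reading: benzyl in place of isopropyl gives no change at the digits printed from compound 2 to compound 4 (within the scatter), so the larger group with its six-membered aromatic ring sits within the scatter of the branched one. Measured against the ethyl group, phenyl in place of methyl on the saturated chain carbon bound to a sulfur gives a 6.3-fold higher number from compound 1 to compound 4 (0.80 log units; beyond the scatter), so a methyl and a phenyl at that carbon each come with a higher number, by a step of the same printed size. Nothing at hand accounts for these readings.

On these data alone, whether a straight chain longer than ethyl, such as n-butyl, would track compound 1 or compounds 2 and 4 remains open. So does the outcome for an amine or a carboxylic acid carried on the benzyl group.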